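Anilide variation on the shared core: cytotoxicity notes

The source may hold more compounds than are shown below. What is called first, only, known or untested is meant among the compounds shown, and "the series" means these compounds.

Compound 1 `CCc1ccc(NC(=O)c2cccc(/C=C3\CC(=O)N(c4ccccc4)C3=O)c2)cc1` is tested in an ADME assay on SW480 cells (Homo sapiens) for cytotoxicity, read by MTT assay, with a stated time of 72 h; on this read-out lower numbers stand for stronger inhibition and higher numbers for weaker inhibition. Compound 1 returns only a limit there, > 100000 nM. Compound 2 `COc1cc(NC(=O)c2cccc(/C=C3\CC(=O)N(c4ccccc4)C3=O)c2)cc(OC)c1OC` also returns only a limit in this assay, > 100000 nM. For the measured compounds named here, both values sit at the limit of > 100000 nM in this assay, at which 2 of the 2 values shown sit, so no measured step is available and compound 1 can be placed no more precisely than that. Compound 3 `CSc1cccc(NC(=O)c2cccc(/C=C3\CC(=O)N(c4ccccc4)C3=O)c2)c1` differs from compound 1 by 3-(methylsulfanyl)phenyl in place of 4-ethylphenyl on an amide-type nitrogen. A step that the limit leaves unreadable from compound 1 to compound 3 is expected, none beyond the scatter. Compound 3 is estimated at 150000 nM in this assay, with a range from 50000 nM to 500000 nM.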

Compound 3, half-maximal inhibitory concentration: 74300 nM
The estimate for compound 3 lay 2.0-fold (0.31 log units) above the measured number, and the stated range covers the measured number.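

Compound 3 returns a number rather than a limit in this assay at this position on the shared core. With 3-(methylsulfanyl)phenyl in place of 4-ethylphenyl on an amide-type nitrogen, the step is an at least 1.3-fold lower number from compound 1 to compound 3 (0.12 log units; that floor lies within the scatter) and so does not establish a real shift in cytotoxicity. The other two compounds remain unquantified: the limit of > 100000 nM in this assay, at which 2 of the 3 values shown sit.

The group's sulfur and its placement on the phenyl change together, so neither can be credited separately. On these data alone, how an amine or a carboxylic acid on that phenyl would read remains open.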